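This account rests on a few compounds, and the source may have more. Where it says the series, first, only, none or still open, it means among the compounds named here.

In an ADME assay on microsomes from liver (Homo sapiens) for metabolic stability, read by LC-MS, using NADPH, tested at 3 uM (on this read-out higher numbers stand for a longer-lived compound and lower numbers for a shorter-lived compound), compound 1 `Cc1ccc2c(C(CC(F)(F)F)c3ccccc3)c(-c3ccccc3)[nH]c2c1` gives 1.45 h and compound 2 `Cc1ccc2c(C(CC(F)(F)F)c3cccs3)c(-c3ccccc3)[nH]c2c1` gives 1.8 h, so compound 2 stands within the scatter of compound 1. Compound 3 `Cc1ccc2c(C(CC(F)(F)F)c3ccco3)c(-c3ccccc3)[nH]c2c1` differs from compound 2 by furan-2-yl in place of thiophen-2-yl on a saturated chain carbon bound to an aromatic carbon and a saturated chain carbon. For the measured compounds named here, the one measured change at that place, thiophen-2-yl in place of phenyl, gave a 1.2-fold higher number from compound 1 to compound 2 (0.09 log units; within the scatter), so no step beyond the scatter is expected in this assay. The estimated step is a 1.1-fold lower number from compound 2 to compound 3 (0.05 log units; within the scatter). Compound 3 is expected at 1.6 h, within an estimated range of 0.9 h to 2.7 h.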

Compound 3, half-life: 0.985 h
For compound 3 the middle estimate is 1.6-fold (0.21 log units) above the measured one, within the range that was stated.
By their numbers in this assay, from the lowest: compounds 3, 1 and 2 (each within the scatter of the next).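

In this assay, furan-2-yl in place of thiophen-2-yl gives a 1.8-fold lower number from compound 2 to compound 3 (0.26 log units; within the scatter) and furan-2-yl in place of phenyl gives a 1.5-fold lower number from compound 1 to compound 3 (0.17 log units; within the scatter). Phenyl, thiophen-2-yl and furan-2-yl on this saturated chain carbon therefore all stand within the scatter of one another, so exchanging the ring sulfur for oxygen gives no step beyond it. No measurement shown bears on the reason for these small steps. As far as these compounds go, whether an amine, a carboxylic acid or a longer chain at this place would give a step beyond the scatter remains open.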